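The compounds below may be only part of what the source reports. "The series", "measured", "known", "first", "only" and "open" are said of these compounds alone.

Measured compounds:
compound 1 `COc1ccc(Cc2ccc3cc(NC(=O)c4ccc(OC(C)=O)c(CC=C(C)C)c4)c(=O)oc3c2C)cc1`, 11500 nM
compound 2 `COc1ccc(Cc2ccc3cc(NC(=O)c4ccc(O)c(CC=C(C)C)c4)c(=O)oc3c2C)cc1`, 13300 nM

Among the measured compounds shown here, in a functional assay on MCF7 cells (Homo sapiens) for antiproliferative activity (on this read-out lower numbers stand for stronger inhibition and higher numbers for weaker inhibition), compound 2 and compound 1 lie within the scatter of each other; the only recorded step, a 1.2-fold higher number from compound 1 to compound 2 (0.06 log units; within the scatter), changes an oxygen substituent on an aromatic ring and leaves the read-out essentially unchanged. Compound 3 `CC(C)=CCc1cc(C(=O)Nc2cc3ccc(Cc4ccc(O)cc4)c(C)c3oc2=O)ccc1O` differs from compound 2 by hydrogen in place of methyl on an oxygen on an aromatic ring. For the measured compounds named here, the one step that bears on it likewise removed a group from an aromatic oxygen and stayed within the scatter, so no movement beyond the scatter is expected in this assay for compound 3, estimated at 13000 nM with a range of 6000 nM to 28000 nM. The expected step is a 1.0-fold lower number from compound 2 to compound 3 (0.01 log units; within the scatter).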

Compound 3, half-maximal inhibitory concentration: 32100 nM
The estimate for compound 3 lay 2.5-fold (0.39 log units) below the measured number, and the stated range ends below it.
By their numbers in this assay, from the lowest: compounds 1 and 2 (each within the scatter of the next); then compound 3.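

In this assay, among the compounds shown here, methoxy to hydroxy on the 4-methoxybenzyl group is the only step here that lies beyond the scatter (a 2.4-fold higher number from compound 2 to compound 3 (0.38 log units; beyond the scatter)), and it goes towards weaker inhibition. This aromatic oxygen is therefore sensitive to its substituent, while removing acetyl from the other aromatic oxygen stayed within the scatter (a 1.2-fold higher number from compound 1 to compound 2 (0.06 log units; within the scatter)). Nothing on hand explains the difference between the two oxygens. Still open, on these data alone, is whether an ethoxy group or an amine at this place would match the methoxy. As far as these compounds go, it is also open whether the same change would cost as much with the acetyl kept on the other oxygen.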